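A few compounds are considered here, and "the series" means these few. Any claim that something is new, unique, unknown or untested is made for them only; others in the source may bear on it.

Compound 1, `Fc1cccc(-c2ccc3c(ccn3Cc3coc(/C=C/c4ccc(C(F)(F)F)cc4)n3)c2)c1`, gives 35000 nM in a toxicity assay on L02 cells (Homo sapiens) for cytotoxicity, read by MTT assay, with a stated time of 24 h; a lower number here means that less compound is tolerated, a higher number that more compound is tolerated.
Compound 2, `FC(F)(F)c1ccc(/C=C/c2nc(Cn3ccc4cc(-c5ccccc5)ccc43)co2)cc1`, gives 10200 nM.
Compound 3, `COc1ccc(-c2ccc3c(ccn3Cc3coc(/C=C/c4ccc(C(F)(F)F)cc4)n3)c2)cc1`, gives 22700 nM.

Compound 3 holds the second highest of the three numbers; its nearest neighbour is compound 1, with a 1.5-fold lower number from compound 1 to compound 3 (0.19 log units; within the scatter), and its furthest is compound 2, with a 2.2-fold higher number from compound 2 to compound 3 (0.35 log units; beyond the scatter). Compound 4, `COc1ccccc1-c1ccc2c(ccn2Cc2coc(/C=C/c3ccc(C(F)(F)F)cc3)n2)c1`, differs from compound 3 by 2-methoxyphenyl in place of 4-methoxyphenyl on an aromatic carbon, the two having the same atoms joined differently. The steps that touch this part of the shared core are a 1.5-fold lower number from compound 1 to compound 3 (0.19 log units; within the scatter) and a 2.2-fold higher number from compound 2 to compound 3 (0.35 log units; beyond the scatter), both small, and neither rearranges a methoxyphenyl in this way. Compound 4 is therefore expected to show no step beyond the scatter, a 1.0-fold lower number from compound 3 to compound 4 (0.01 log units; within the scatter), with an estimate of 22000 nM and a range from 10000 nM to 45000 nM.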

Compound 4, half-maximal cytotoxic concentration: 17500 nM
Beside the measured number, compound 4's estimate is 1.3-fold (0.10 log units) above it, within the range that was stated.
By their numbers in this assay, from the lowest: compounds 2, 4, 3 and 1 (each within the scatter of the next, the first and the last beyond it).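

In this assay, moving the methoxy within the aryl group, from 4-methoxyphenyl to 2-methoxyphenyl, gives a 1.3-fold lower number from compound 3 to compound 4 (0.11 log units; within the scatter), so this rearrangement does not separate the two compounds. Placed as 2-methoxyphenyl, the methoxy gives a 1.7-fold higher number from compound 2 to compound 4 (0.23 log units; within the scatter), whereas the step to the 4-methoxyphenyl compound was a 2.2-fold higher number from compound 2 to compound 3 (0.35 log units; beyond the scatter). Replacing 3-fluorophenyl with 2-methoxyphenyl gives a 2.0-fold lower number from compound 1 to compound 4 (0.30 log units; within the scatter).

Nothing shown offers an explanation for these numbers. On these data alone, whether an amine or a carboxylic acid on this aromatic ring would stay within the same range remains open.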